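Replacing phenyl with a boron group: cell toxicity

The compounds below may be only part of what the source reports. "The series", "measured", "known", "first", "only" and "open" are said of these compounds alone.

In a toxicity assay on MDCK cells (Canis lupus familiaris) for cytotoxicity, read by CCK-8 assay, with a stated time of 48 h (on this read-out lower numbers stand for higher toxicity in this test and higher numbers for lower toxicity in this test), compound 1 (`CCCOc1ccc(C(=O)NNc2c(Br)cccc2Br)cc1`) gives > 100000 nM, which is a limit of the assay and not a number. Compound 2 (`O=C(NNc1c(Br)cccc1Br)c1ccc(Br)cc1`) gives > 100000 nM, again a limit. Among the compounds with values here, compound 3 (`O=C(NNc1c(Br)cccc1Br)c1ccc(-c2ccccc2)cc1`) gives 84100 nM, the only true number among the three.

Compound 4 (`O=C(NNc1c(Br)cccc1Br)c1ccc(B(O)O)cc1`) differs from compound 3 in one place: a group of 3 heavy atoms (1 boron, 2 oxygen; no ring) in place of a group of 6 heavy atoms (6 carbon; one six-membered aromatic ring of carbon only), on an aromatic carbon. The phenyl leaves, and a group with no ring enters.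

Two measured steps involve this same aromatic carbon: an at least 1.1-fold lower number from compound 1 to compound 3 (0.07 log units; that floor lies within the scatter) and an at least 1.1-fold lower number from compound 2 to compound 3 (0.07 log units; that floor lies within the scatter). Neither floor goes beyond the scatter. The third, a step that the two limits leave unreadable from compound 1 to compound 2, cannot be read at all. All three touch (the limit of > 100000 nM in this assay, at which 2 of the 3 values shown sit), so the data show no exchange at this carbon that clearly moves the result in this assay.

No step beyond the scatter is therefore expected, and the estimated change is a 1.2-fold higher number from compound 3 to compound 4 (0.08 log units; within the scatter). For compound 4 the estimated value is 100000 nM, with an expected range from 40000 nM to 250000 nM.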

Compound 4, half-maximal cytotoxic concentration: > 100000 nM
Compound 4: a limit, no number (the forecaster's own chance of this, stated with the estimate: 60%); the middle value sits exactly at the limit.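

In this assay compound 4 gives > 100000 nM, which is a limit and not a number, so the boron group, the first group shown at this aromatic carbon that carries hydrogen-bond donors, brings no toxicity that this test can put a number on. Within the data shown here, the one readable step, an at least 1.1-fold higher number from compound 3 to compound 4 (0.07 log units; that floor lies within the scatter), shows no clear change on losing the phenyl. The steps to compound 4 from compound 1 and from compound 2 cannot be read, and the results at this carbon stay crowded against the top of the test: the limit of > 100000 nM in this assay, at which 3 of the 4 values shown sit.

An amine, a carboxylic acid or a longer chain at this carbon lies outside the compounds shown, so whether any group here can move the number beyond the scatter stays open. From the compounds shown here alone, how far compound 1, compound 2 and compound 4 differ from one another also stays open.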